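Allyl for Pentyl Ether on the Ethyl Ester Core

This account rests on a few compounds, and the source may have more. Where it says the series, first, only, none or still open, it means among the compounds named here.

Compound 1 `CCCCCOc1ccccc1-c1ncc(C(=O)O)c(=O)[nH]1` is the starting point of this small set. In a functional assay on the whole organism (strain Sprague-Dawley) for inhibition, with Rattus norvegicus as the target, with a stated time of 10 min (on this read-out higher numbers stand for an effect only at larger amounts of compound and lower numbers for an effect already at smaller amounts), compound 1 gives 3 mg/kg. Compound 2 `C=CCOc1ccccc1-c1ncc(C(=O)O)c(=O)[nH]1` differs from it by vinyl in place of butyl on a saturated chain carbon bound to an oxygen on an aromatic ring, and in this assay compound 2 gives 0.5 mg/kg. This single change made a 6.0-fold lower number from compound 1 to compound 2 (0.78 log units; beyond the scatter), so the shorter allyloxy chain worked at a smaller dose than the pentyloxy chain.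

Compound 3 `CCCCCOc1ccccc1-c1ncc(C(=O)OCC)c(=O)[nH]1` differs from compound 1 in the core, by ethyl in place of hydrogen on an oxygen next to a carbonyl group. In this assay compound 3 gives 2 mg/kg, which amounts to a 1.5-fold lower number from compound 1 to compound 3 (0.18 log units; within the scatter); the two compounds therefore cannot be told apart on this read-out.

Compound 4 `C=CCOc1ccccc1-c1ncc(C(=O)OCC)c(=O)[nH]1` has not yet been measured. It differs from compound 3 by vinyl in place of butyl on a saturated chain carbon bound to an oxygen on an aromatic ring, which is the same change that turned compound 1 into compound 2, made at the same place and on the same kind of chain carbon. Going by the values given here, only one measured pair shows this change, so the expectation for compound 4 rests on that pair alone. Among the compounds with values here, compound 4 is expected to give 0.35 mg/kg in this assay, which would be a step of a 5.7-fold lower number from compound 3 to compound 4 (0.76 log units; beyond the scatter), because a 6.0-fold lower number from compound 1 to compound 2 (0.78 log units; beyond the scatter) is the only guide for the same change on a core that behaves like compound 1. Compound 4 is estimated to fall between 0.12 mg/kg and 1 mg/kg.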

Compound 4, dose for 50% inhibition: 0.5 mg/kg
The estimate for compound 4 lay 1.4-fold (0.15 log units) below the measured number; low and high end bracket the measured number.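

In this assay the change from pentyl to allyl carried over from the core of compound 1 to the core of compound 3, where it gave a 4.0-fold lower number from compound 3 to compound 4 (0.60 log units; beyond the scatter), and the two steps do not differ: the same change on two cores in this assay, a 6.0-fold lower number (0.78 log units; beyond the scatter) from compound 1 to compound 2 and a 4.0-fold lower number (0.60 log units; beyond the scatter) from compound 3 to compound 4, 1.5-fold (0.18 log units) apart, within the scatter of two such steps.

The other change in this square, ethyl in place of hydrogen on an oxygen next to a carbonyl group, also behaved alike in both settings, with no change at the digits printed from compound 2 to compound 4 (within the scatter) in the allyl pair, so it made no readable difference on either chain: the same change on two cores in this assay, a 1.5-fold lower number (0.18 log units; within the scatter) from compound 1 to compound 3 and no change at the digits printed (within the scatter) from compound 2 to compound 4, 1.5-fold (0.18 log units) apart, within the scatter of two such steps.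

Going by these compounds alone, this shows that, across these four compounds, the effect of the chain change held whichever of the two cores carried it, but it rests on only two pairs, and those cores differ from each other in a single place, so it does not show that the step would survive on a core changed in any other way.

The compounds shown leave open whether the step follows from the shorter chain or from the double bond, a question that a propyl chain in place of the pentyl could separate. They also leave open how the chain change would behave with an amide in place of the carboxylic acid.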